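This account rests on a few compounds, and the source may have more. Where it says the series, first, only, none or still open, it means among the compounds named here.

Measured compounds in a functional assay on CHO cells for agonist activity at Free fatty acid receptor 1 (Homo sapiens), read by FLIPR and calcium flux; on this read-out lower numbers stand for an effect already at smaller amounts and higher numbers for an effect only at larger amounts of compound:
compound 1, `Cc1nc(-c2ccccc2)sc1COc1ccc(S(=O)(=O)CC(=O)O)cc1`, 331 nM
compound 2, `Cc1nc(-c2ccccc2F)sc1COc1ccc(S(=O)(=O)CC(=O)O)cc1`, 550 nM
compound 3, `Cc1nc(-c2ccc(F)cc2)sc1COc1ccc(S(=O)(=O)CC(=O)O)cc1`, 191 nM

Compound 3 holds the lowest of the three numbers in this assay, but its gap to compound 1 is within the scatter, so the two cannot be ordered; only compound 2 stands apart from it, as the step of a 2.9-fold lower number from compound 2 to compound 3 (0.46 log units; beyond the scatter) shows. Compound 4, `Cc1nc(-c2cccc(Cl)c2)sc1COc1ccc(S(=O)(=O)CC(=O)O)cc1`, has not yet been measured in this assay. It differs from compound 3 in one place: 3-chlorophenyl in place of 4-fluorophenyl on an aromatic carbon.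

Within the data shown here, three measured steps bear on this change, all of them moving a halogen around the same phenyl ring. The step of a 1.7-fold lower number from compound 1 to compound 3 (0.24 log units; within the scatter) and the step of a 1.7-fold higher number from compound 1 to compound 2 (0.22 log units; within the scatter) are each within the scatter, while the step of a 2.9-fold lower number from compound 2 to compound 3 (0.46 log units; beyond the scatter) is modest. Swapping one halogen for another and shifting its place on the ring has therefore given only small movements so far; the 3-chlorophenyl group has no measured counterpart. Compound 4 is expected to give about 260 nM in this assay, within 110 nM to 620 nM, which means an estimated step of a 1.4-fold higher number from compound 3 to compound 4 (0.13 log units; within the scatter).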

Compound 4, half-maximal effective concentration: 251 nM
Compound 4: middle estimate off by 1.0-fold (0.02 log units), on the high side, within the range that was stated.
By their numbers in this assay, from the lowest: compounds 3, 4, 1 and 2 (each within the scatter of the next, the first and the last beyond it).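

In this assay, a chloro group now joins the fluoro groups on this phenyl ring, and the step of a 1.3-fold higher number from compound 3 to compound 4 (0.12 log units; within the scatter) and the step of a 1.3-fold lower number from compound 1 to compound 4 (0.12 log units; within the scatter) both stay within the scatter, so the 3-chlorophenyl group cannot be told apart from the 4-fluorophenyl group or from the plain phenyl group. The step of a 2.2-fold lower number from compound 2 to compound 4 (0.34 log units; beyond the scatter) goes beyond the scatter, which leaves compound 2, with its 2-fluorophenyl group, apart from both compound 3 and compound 4. No measured evidence bears on the reason for these values.

As far as these compounds go, it remains open how the 2-chlorophenyl and 4-chlorophenyl groups would compare with the 3-chlorophenyl group. The same holds for phenyl rings carrying something other than a halogen, such as a methoxy group, an amine or a carboxylic acid.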